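The source may hold more compounds than are shown below. What is called first, only, known or untested is meant among the compounds shown, and "the series" means these compounds.

Compound 1 `O=c1c2cnn(-c3ccc(F)cc3)c2ncn1CC1(O)CCN(Cc2ccncc2)CC1`, compound 2 `O=c1c2cnn(-c3ccc(F)cc3)c2ncn1CC1(O)CCN(Cc2ccc(Br)cc2)CC1` and compound 3 `O=c1c2cnn(-c3ccc(F)cc3)c2ncn1CC1(O)CCN(Cc2ccc(F)cc2Cl)CC1` share one core and differ only in the aromatic group carried on a saturated chain carbon bound to an amine nitrogen in a ring. In an assay on Sf21 cells for inhibition of ubiquitin carboxyl-terminal hydrolase 7 (Homo sapiens), read by spectrophotometry, with stated times of 30 min and 2 h (on this read-out higher numbers stand for weaker inhibition and lower numbers for stronger inhibition), compound 1 gives "not determined" (no result reported), so no number is available for it. In this assay compound 2 gives 6700 nM and compound 3 gives 1600 nM. Among the measured compounds shown here, the single measured step is a 4.2-fold lower number from compound 2 to compound 3 (0.62 log units; beyond the scatter). On the two numbers shown, compound 3 stands lowest, with compound 2 the only neighbour.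

Compound 4 `COC(=O)c1ccc(CN2CCC(O)(Cn3cnc4c(cnn4-c4ccc(F)cc4)c3=O)CC2)c(F)c1` is the next step from compound 3, (2-fluoro-4-(methoxycarbonyl)phenyl in place of 2-chloro-4-fluorophenyl on a saturated chain carbon bound to an amine nitrogen in a ring). The only measured step that touches the same place is the one from compound 2 to compound 3, and it exchanged one halogenated ring for another; neither measured compound carries a methoxycarbonyl group, so nothing shown speaks directly to this change. The size of that step suggests that swaps at this position can move the number modestly, in either direction. Compound 4 is therefore expected to stay close to compound 3, with an estimated 1.3-fold higher number from compound 3 to compound 4 (0.10 log units; within the scatter) and an estimated value of 2000 nM, within a range from 500 nM to 8000 nM.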

Compound 4, half-maximal inhibitory concentration: 800 nM
Beside the measured number, compound 4's estimate is 2.5-fold (0.40 log units) above it; measured number inside the range.
By their numbers in this assay, from the lowest: compounds 4 and 3 (each within the scatter of the next); then compound 2.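

In this assay, a 2-fluoro-4-(methoxycarbonyl)phenyl group is accepted on a saturated chain carbon bound to an amine nitrogen in a ring, and the exchange for 2-chloro-4-fluorophenyl gives a 2.0-fold lower number from compound 3 to compound 4 (0.30 log units; within the scatter), so compound 3 and compound 4 cannot be told apart on this read-out. Measured against the 4-bromophenyl group, the same methoxycarbonyl-bearing ring gives an 8.4-fold lower number from compound 2 to compound 4 (0.92 log units; beyond the scatter), and with a 4.2-fold lower number from compound 2 to compound 3 (0.62 log units; beyond the scatter) this places both compound 3 and compound 4 clear of compound 2, although the rings of compound 3 and compound 4 carry different groups and only the latter has hydrogen-bond acceptors. No measurement offered here accounts for any of these steps.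

It remains open whether the methoxycarbonyl group itself contributes anything at this position, since neither a carboxylic acid nor a primary amide in its place, nor a ring with the 2-fluoro group alone, appears among these compounds. Going by these compounds, compound 1 gives "not determined" (no result reported) in this assay, so its steps to the other compounds cannot be read, and the effect of its ring nitrogen stays unknown.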